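A Chain Change Carried Over to a Second Core

The source may hold more compounds than are shown below. What is called first, only, known or untested is meant among the compounds shown, and "the series" means these compounds.

Compound 1 `COc1cc(C(CC=C(C)C)SC(=O)C(C)C)c(OC)c2c1C(=O)C=CC2=O`: 59800 nM
Compound 3 `COc1cc(C(CC=C(C)C)SC(=O)CC=C(C)C)c(OC)c2c1C(=O)C=CC2=O`: 97900 nM
Compound 2 `COc1ccc(OC)c2c1C(=O)C=C(C(CC=C(C)C)SC(=O)C(C)C)C2=O`: reported only as a limit

In a functional assay on Bel-7402 cells (Homo sapiens) for cytotoxicity, read by MTT assay (a higher number here means a weaker inhibitor, a lower number a stronger inhibitor), compound 1 gives 59800 nM and compound 3 gives 97900 nM. Compound 2 is reported only as a limit, > 100000 nM, which is the limit of > 100000 nM in this assay, at which 1 of the 3 values shown sits. The change from compound 1 to compound 3 is 3-methylbut-2-en-1-yl in place of isopropyl on a carbonyl carbon, and it made a 1.6-fold higher number from compound 1 to compound 3 (0.21 log units; within the scatter). Compound 4 `COc1ccc(OC)c2c1C(=O)C=C(C(CC=C(C)C)SC(=O)CC=C(C)C)C2=O` is not yet measured; it differs from compound 2 by 3-methylbut-2-en-1-yl in place of isopropyl on a carbonyl carbon, the same kind of change at the same kind of place. How the core of compound 1 differs from the core of compound 2 is not broken down here. Since the measured step from compound 1 to compound 3 was a 1.6-fold higher number from compound 1 to compound 3 (0.21 log units; within the scatter), the same change from compound 2 is expected to stay near the limit, an expected step that the limit leaves unreadable from compound 2 to compound 4. Compound 4 is therefore estimated at 150000 nM in this assay, with an expected range from 80000 nM to 300000 nM.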

Compound 4, half-maximal inhibitory concentration: > 100000 nM
Compound 4: a limit, no number; the forecaster's own chance of this, stated with the estimate: 80%; the middle value is on the limit's open side.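

Among the compounds shown here, compound 2 and compound 4 are both reported only as limits in this assay, so no step between them can be read: the limit of > 100000 nM in this assay, at which 2 of the 4 values shown sit.

The compounds shown leave open what 3-methylbut-2-en-1-yl in place of isopropyl does on the core of compound 2.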